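Amide nitrogen substituent exchange on a shared alkyne core

The source may report more compounds than this note shows. Statements on the series, on what has been measured and on what is new or still open speak of the compounds shown alone.

Measured compounds:
- Compound 1, `C[C@@H](NC(=O)c1ccc(C#Cc2cccc(F)c2)nc1)C(C)(C)O`, in a functional assay on HEK293 cells for positive allosteric modulation of metabotropic glutamate receptor 5 (Rattus norvegicus), read by fluorescence and calcium flux; on this read-out lower numbers stand for smaller maximal responses and higher numbers for larger maximal responses: compound 1 gives 64.9%
- Compound 2, `C[C@@H](NC(=O)c1ccc(C#Cc2cccc(F)c2)nn1)C(C)(C)O`, in this assay: compound 2 gives 70.2%
- Compound 3, `C[C@@H](NC(=O)c1ccc(C#Cc2cccc(F)c2)cn1)C(C)(C)C`, in this assay: compound 3 gives 66%

All three measured compounds share the alkyne-linked aryl core and differ in the ring atoms of the amide-bearing heterocycle and in the group on the amide nitrogen. Their maximal responses in this assay sit close together: the value of compound 3 lies among those of compound 1 and compound 2, and both differences fall within the usual scatter, so no ordering among the three can be claimed.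

Compound 4, `O=C(NCC1CC1)c1ccc(C#Cc2cccc(F)c2)cn1`, keeps the core of compound 3 and alters only the amide nitrogen substituent: cyclopropylmethyl in place of 1,2,2-trimethylpropyl on an amide-type nitrogen. The new group is a smaller, unbranched chain bearing a three-membered ring, and the defined stereocentre of compound 3 is lost.

Going by the values given here, no pair of measured compounds isolates this kind of change, so the expectation rests on the narrow spread of the three known values. For this assay the step is expected to be none beyond the scatter, with an estimated step of a number 4 percentage points lower from compound 3 to compound 4 (within the scatter). Compound 4 is accordingly estimated at 62% in this assay, within a range from 45% to 80%.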

Compound 4, largest response reached (reported as efficacy), in percent of the reference or control that the assay uses: 61.4%
For compound 4 the middle estimate is 0.6 percentage points above the measured one; the range from low to high includes it.
By their numbers in this assay, from the lowest: compounds 4, 1, 3 and 2 (each within the scatter of the next).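

In this assay, cyclopropylmethyl in place of 1,2,2-trimethylpropyl on an amide-type nitrogen gives the first step read with the core held constant, and it reads a number 4.6 percentage points lower from compound 3 to compound 4 (within the scatter). On this single pair, the maximal response shows no change beyond the scatter when the group on the amide nitrogen loses its defined stereocentre and gains a three-membered ring, so this position accepts both substituents in this read-out. No evidence is available that would explain this result.

Open, going by these compounds, is whether the same exchange behaves alike on the cores of compound 1 and compound 2, since this single step rests on the core of compound 3. Also open, on these data alone, is how the maximal response answers to an amide nitrogen carrying a longer chain, a carboxylic acid or an amine.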